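Methylating a Hydroxy Group in Two Different Settings

The source may report more compounds than this note shows. Statements on the series, on what has been measured and on what is new or still open speak of the compounds shown alone.

Of the compounds shown here, three built on a shared core have been measured in a functional assay on KB cells (Homo sapiens) for cytotoxicity, read by resazurin assay, with a stated time of 3 days; on this read-out higher numbers stand for weaker inhibition and lower numbers for stronger inhibition. Compound 1 `COc1cc(C(=O)NCC(C)(C)CC2=C(O)C(=O)c3ccccc3C2=O)c(O)c2ccccc12` gives 8620 nM. Compound 3 `COc1cc(C(=O)NCC(C)(C)CC2=C(O)C(=O)c3ccccc3C2=O)c(OC)c2ccccc12` gives 47000 nM; the step of a 5.5-fold higher number from compound 1 to compound 3 (0.74 log units; beyond the scatter) is the change (methyl in place of hydrogen on an oxygen on an aromatic ring). Compound 2 `COc1ccc(OC)c(C(=O)NCC(C)(C)CC2=C(O)C(=O)c3ccccc3C2=O)c1` gives 86600 nM; the difference between the cores of compound 2 and compound 1 is not broken down here, and the values of compound 2 and compound 3 lie within the scatter of each other, while compound 2 stands beyond the scatter from compound 1.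

Compound 4 `COC1=C(CC(C)(C)CNC(=O)c2cc(OC)ccc2OC)C(=O)c2ccccc2C1=O` has not yet been measured. It differs from compound 2 by methyl in place of hydrogen on an oxygen on an unsaturated carbon. Going by the values given here, this is the same kind of change as the one from compound 1 to compound 3, but not the same: there the oxygen sits on an aromatic ring whose other neighbours are aromatic carbon, here on an unsaturated carbon whose other neighbour is a double-bonded ring carbon.

Resting only on the step of a 5.5-fold higher number from compound 1 to compound 3 (0.74 log units; beyond the scatter) seen for compound 1 and compound 3, a step of similar size and direction, a 2.3-fold higher number from compound 2 to compound 4 (0.36 log units; beyond the scatter), is expected in this assay. Compound 4 is therefore estimated at 200000 nM, between 60000 nM and 600000 nM, with a real chance that only a limit is reported.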

Compound 4, half-maximal inhibitory concentration: 34300 nM
Estimate against measurement, compound 4: 5.8-fold (0.77 log units) above; the whole stated range lies above it.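

In this assay the change from hydroxy to methoxy on the unsaturated carbon brings a 2.5-fold lower number from compound 2 to compound 4 (0.40 log units; beyond the scatter). Set beside the same methylation on the aromatic ring, this step runs the other way, so in this series neither the size nor the direction of the change can be carried from one core to another: the same change on two cores in this assay, a 5.5-fold higher number (0.74 log units; beyond the scatter) from compound 1 to compound 3 and a 2.5-fold lower number (0.40 log units; beyond the scatter) from compound 2 to compound 4, 14-fold (1.14 log units) apart, beyond the scatter of two such steps What this does not show is the reason for the difference: the two oxygens stand in different settings, the cores differ as well, and two pairs of compounds make no general rule.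

The compounds shown leave open whether the opposite directions follow the setting of the oxygen or the rest of the core, as each setting is seen methylated on one core alone. They also leave open what a longer chain such as ethyl or an acetyl group on that oxygen, or an amine in place of the hydroxy, would do in this assay.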